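The compounds below may be only part of what the source reports. "The series", "measured", "known", "first", "only" and "open" are said of these compounds alone.

Measured so far:
Compound 1 `CNc1nc(NCc2ccc(Cl)cc2)cc(-c2ccccn2)n1`: in a functional assay on HEK293 cells for agonist activity at G-protein coupled receptor 39 (Homo sapiens), read by inositol phosphate accumulation (a higher number here means that more compound is needed for the effect, a lower number that less compound is needed), compound 1 gives 15 nM.
Compound 2 `CNc1nc(NCc2ccc(NC(C)=O)cc2)cc(-c2ccccn2)n1`: in this assay compound 2 gives 5 nM.

Within the data shown here, compound 2 holds the lowest of the two numbers; the only step seen is a 3.0-fold lower number from compound 1 to compound 2 (0.48 log units; beyond the scatter). Compound 3 `CNc1nc(NCc2ccc(N(C)C(C)=O)cc2)cc(-c2ccccn2)n1` differs from compound 2 by methyl in place of hydrogen on an amide-type nitrogen. Among the measured compounds shown here, no measured step touches the amide-type nitrogen; the step of a 3.0-fold lower number from compound 1 to compound 2 (0.48 log units; beyond the scatter) changes the group on the aromatic ring and bears on this change only indirectly. The numbers give no direction, so for compound 3 the expected step in this assay is a 2.0-fold higher number from compound 2 to compound 3 (0.30 log units; within the scatter), a small one. Compound 3 is estimated at 10 nM, range 3 nM to 40 nM.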

Compound 3, half-maximal effective concentration: 1180 nM
Beside the measured number, compound 3's estimate is 120-fold (2.07 log units) below it, outside the stated range (above it).
By their numbers in this assay, from the lowest: compound 2; then compound 1; then compound 3.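

The amide-type nitrogen proves far more sensitive than the earlier change on the aromatic carbon: in this assay, methyl in place of the amide hydrogen gives a 240-fold higher number from compound 2 to compound 3 (2.37 log units; beyond the scatter) and so reverses the gain seen with acetamido. Acetyl(methyl)amino in place of chloro gives a 79-fold higher number from compound 1 to compound 3 (1.90 log units; beyond the scatter) and leaves compound 3 with the highest number of the three. Nothing measured here bears on the cause of this loss.
Open, going by these compounds, is whether the loss is specific to methyl or extends to ethyl or a longer chain on this nitrogen. Also open, on these data alone, is how a methanesulfonamide or a urea in place of acetamido would read.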